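Swapping the Five-Membered Ring for a Cyanophenyl Group

The source may report more compounds than this note shows. Statements on the series, on what has been measured and on what is new or still open speak of the compounds shown alone.

Compound 1, `O=C(/C=C/c1cccc(O)c1)c1cc(O)c(O)c([N+](=O)[O-])c1`: 43900 nM
Compound 2, `CC(=O)N1N=C(c2cc(O)c(O)c([N+](=O)[O-])c2)CC1c1nccs1`: 84600 nM
Compound 3, `CC(=O)N1N=C(c2cc(O)c(O)c([N+](=O)[O-])c2)CC1c1cccs1`: 86300 nM

Of the compounds shown here, three have been measured in an assay on isolated protein for inhibition of Amine oxidase [flavin-containing] A (Homo sapiens), read by fluorescence (on this read-out higher numbers stand for weaker inhibition and lower numbers for stronger inhibition), and all three share the same nitro-catechol fragment. The numbers for compound 3, compound 2 and compound 1 lie within the usual scatter of one another, so none of them stands apart from the rest.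

The next compound, compound 4, `CC(=O)N1N=C(c2cc(O)c(O)c([N+](=O)[O-])c2)CC1c1ccc(C#N)cc1`, differs from compound 3 in one place: 4-cyanophenyl in place of thiophen-2-yl on a saturated ring carbon. Within the data shown here, only one measured step touches this position, namely a 1.0-fold higher number from compound 2 to compound 3 (0.01 log units; within the scatter), which exchanged one five-membered ring for another and left the number essentially unchanged. Among the measured compounds shown here, no measured compound carries a six-membered carbon-only ring or a nitrile at this position, so the present change reaches beyond what the data have tested. Given that the one known change here did nothing beyond the scatter, the step of a 1.1-fold lower number from compound 3 to compound 4 (0.03 log units; within the scatter) is expected to be small in either direction. Compound 4 is therefore estimated at 80000 nM, with a range from 30000 nM to 220000 nM.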

Compound 4, half-maximal inhibitory concentration: 76600 nM
For compound 4 the middle estimate is 1.0-fold (0.02 log units) above the measured one; the range from low to high includes it.
By their numbers in this assay, from the lowest: compounds 1, 4, 2 and 3 (each within the scatter of the next).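

In this assay, this position on the saturated ring carbon has so far held only five-membered aromatic rings, and it now also accepts a six-membered aromatic ring of carbon only, bearing a nitrile. Putting 4-cyanophenyl in place of thiophen-2-yl gives a 1.1-fold lower number from compound 3 to compound 4 (0.05 log units; within the scatter) and putting it in place of 1,3-thiazol-2-yl gives a 1.1-fold lower number from compound 2 to compound 4 (0.04 log units; within the scatter), so all three aromatic groups give numbers within the scatter of one another, even though the entering group is larger by heavy-atom count. No measurement shown here accounts for this result.

The compounds shown leave open whether an amine, a carboxylic acid or a longer alkyl chain at this position would give a number outside that scatter. They also leave open how a plain phenyl ring without the nitrile would compare.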